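The source may hold more compounds than are shown below. What is called first, only, known or untested is meant among the compounds shown, and "the series" means these compounds.

Compound 1 `CNC(=O)Nc1c(C)nc2c(OCc3ccccc3)cccn12` gives 27% in a functional assay on the whole organism with Canis familiaris (Canis lupus familiaris) as the target, at a dose of 5 mg/kg by the intravenous route; on this read-out higher numbers stand for a stronger effect at the one dose given and lower numbers for a weaker effect. Compound 2 `CCNc1c(C)nc2c(OCc3ccccc3)cccn12` gives 70% in this assay. The step of a number 43 percentage points higher from compound 1 to compound 2 (beyond the scatter) lies beyond the scatter. Among the measured compounds shown here, compound 2 thus stands highest of the two numbers so far, with compound 1 as its only neighbour. Compound 3 `Cc1nc2c(OCc3ccccc3)cccn2c1NC(C)C` differs from compound 2 by methyl in place of hydrogen on a saturated chain carbon bound to a nitrogen on an aromatic ring and a saturated chain carbon. For the measured compounds named here, the single measured step concerns the group on the ring nitrogen and not the chain carbon, so it does not speak to this change, and no measured pair does. The step of a number 5 percentage points lower from compound 2 to compound 3 (within the scatter) is therefore expected to stay within the scatter. Compound 3 is estimated at 65%, with a range of 45% to 85% in this assay.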

Compound 3, a percentage reported as inhibition, in the whole organism at one dose (the size of the read-out at that dose, not a potency): 0%
The estimate for compound 3 lay 65 percentage points above the measured number; measured number below the stated range.
By their numbers in this assay, from the lowest: compound 3; then compound 1; then compound 2.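

On the nitrogen on an aromatic ring, one methyl added to the saturated chain carbon, ethylamino to isopropylamino, gives a number 70 percentage points lower from compound 2 to compound 3 (beyond the scatter) in this assay and removes the gain seen with ethyl. Isopropyl also falls short of methylcarbamoyl, with a number 27 percentage points lower from compound 1 to compound 3 (beyond the scatter) as the step, so among these three groups the read-out does not follow from the mere replacement of methylcarbamoyl by an alkyl group. As far as these compounds go, whether a straight propyl chain or a free amine at this nitrogen would keep the read-out stays open. Nothing measured here explains the loss with isopropyl.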